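The source may hold more compounds than are shown below. What is called first, only, known or untested is meant among the compounds shown, and "the series" means these compounds.

Measured values in a functional assay on DU-145 cells (Homo sapiens) for inhibition; on this read-out lower numbers stand for stronger inhibition of growth and higher numbers for weaker inhibition of growth:

compound 1 `O=S(=O)(/C=C/c1ccccc1)Cc1ccc(Nc2ncnc3ccccc23)cc1` gives 2000 nM
compound 2 `O=S(=O)(/C=C/c1ccc(F)cc1)Cc1ccc(Nc2ncnc3ccccc23)cc1` gives 300 nM
compound 3 `O=S(=O)(/C=C/c1ccc(Cl)cc1Cl)Cc1ccc(Nc2ncnc3ccccc23)cc1` gives 3000 nM

Compound 3 cannot be told apart from compound 1, since the step between them is within the scatter: a 1.5-fold higher number from compound 1 to compound 3 (0.18 log units; within the scatter). Compared with compound 2, it has the clearly higher number, which means weaker inhibition of growth: a 10-fold higher number from compound 2 to compound 3 (1.00 log units; beyond the scatter).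

Compound 4 `O=S(=O)(/C=C/c1ccc(Cl)cc1Cl)Cc1ccc(Nc2ncnc3ccc(Br)cc23)cc1` keeps everything in compound 3 except for one change in the shared core: bromo in place of hydrogen on an aromatic carbon. This is bromo in place of hydrogen on an aromatic carbon, in a ring that is part of a fused or bridged system of two rings.

Among the compounds with values here, no measured step changes the shared core, so the evidence is only indirect. The closest parallel is also a halogen swap on an aromatic carbon, but on the phenyl group, and it was modest: a 6.7-fold lower number from compound 1 to compound 2 (0.82 log units; beyond the scatter). The dichloro swap on that same phenyl group moved the number by no more than the scatter: a 1.5-fold higher number from compound 1 to compound 3 (0.18 log units; within the scatter). Halogens have therefore given mixed results here, and no direction can be firmly expected in this assay. The expected outcome is a small change, with the estimate meaning a 1.5-fold lower number from compound 3 to compound 4 (0.18 log units; within the scatter). For compound 4 the estimated value is 2000 nM, with an expected range from 400 nM to 10000 nM.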

Compound 4, concentration for 50% growth inhibition: 2000 nM
Estimate against measurement, compound 4: no gap at the digits printed, and the stated range covers the measured number.
By their numbers in this assay, from the lowest: compound 2; then compounds 1, 4 and 3 (each within the scatter of the next).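

In this assay, the one step shown in the shared core, bromo in place of hydrogen on an aromatic carbon, gives a 1.5-fold lower number from compound 3 to compound 4 (0.18 log units; within the scatter) and so cannot be told apart from no change at all. This carbon, in a ring that is part of a fused system of two rings, therefore accepts a single bromine atom with no measurable loss of growth inhibition, at least when the 2,4-dichlorophenyl group is present. Until now, only the phenyl group had been varied, and there a halogen could matter, as fluoro did with a 6.7-fold lower number from compound 1 to compound 2 (0.82 log units; beyond the scatter), whereas this halogen on the core leaves the number within the scatter. No measurement shown here explains why the bromo has so little effect on this read-out.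

The compounds shown leave open whether the same bromo would also make no clear difference alongside the 4-fluorophenyl group of compound 2, which stands clearly apart from compounds 1 and 3. They also leave open whether a larger or very different group on this carbon, such as an amine or a carboxylic acid, would be accepted as well as the bromo.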